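The compounds below may be only part of what the source reports. "The series", "measured", "known", "first", "only" and "open" are said of these compounds alone.

Compound 2 `CC(C)C[C@H](N)c1cc(C(F)(F)F)ccc1N1CCN(C(=O)COc2cccc(Cl)c2Cl)CC1` was examined in an assay on HEK293 cells for displacement of a labelled ligand from Melanocortin receptor 4 (Homo sapiens) (a higher number here means a weaker inhibitor, a lower number a stronger inhibitor), where compound 2 gives 2500 nM. Among the three compounds measured so far this is the highest number. Compound 1 `Cc1ccc(N2CCN(C(=O)[C@H](C)Cc3ccc(Cl)cc3F)CC2)c([C@@H](N)CC(C)C)c1` gives 20 nM in this assay, and compound 3 `CC(C)C[C@H](N)c1cc(F)ccc1N1CCN(C(=O)C(C)Cc2ccc(Cl)cc2)CC1` gives 390 nM. Compound 3 thus stands nearest to compound 2 and compound 1 furthest from it, and both gaps lie beyond the usual scatter of repeated measurements.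

Compound 4 `CC(C)C[C@H](N)c1cc(C(F)(F)F)ccc1N1CCN(C(=O)COc2cccc(Cl)c2)CC1` has not yet been measured. It differs from compound 2 in a single place: hydrogen in place of chloro on an aromatic carbon. The chloro that leaves sits on an aromatic carbon of a six-membered aromatic ring of carbon only, ortho to a chloro group and ortho to a large group, so that the 2,3-dichlorophenoxy of compound 2 becomes the 3-chlorophenoxy of compound 4. Among the compounds with values here, no pair of measured compounds differs in exactly this way, so no step of this kind can be read off from the numbers in hand. The expectation is that the step of a 1.4-fold higher number from compound 2 to compound 4 (0.15 log units; within the scatter) will be modest, leaning if anything toward a higher number, and quite possibly not beyond the scatter. Compound 4 is estimated at 3500 nM, with a range from 1200 nM to 10000 nM.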

Compound 4, inhibition constant: 2600 nM
Beside the measured number, compound 4's estimate is 1.3-fold (0.13 log units) above it; measured number inside the range.
By their numbers in this assay, from the lowest: compound 1; then compound 3; then compounds 2 and 4 (each within the scatter of the next).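

With compound 2 and compound 4, the series gains its first pair differing in one place, and the result in this assay is a 1.0-fold higher number from compound 2 to compound 4 (0.02 log units; within the scatter). On this aromatic carbon, ortho to a chloro group and ortho to a large group, hydrogen in place of chloro therefore leaves no change that can be separated from the scatter, and in this setting the 2,3-dichlorophenoxy and 3-chlorophenoxy compounds cannot be told apart. Nothing available accounts for this result, so the reading stays a plain observation on this single pair.

The compounds shown leave open whether a methoxy group, a fluoro or a nitrile on this same aromatic carbon would read the same way, and whether the chloro that remains in the 3-chlorophenoxy group matters, as a bare phenoxy group would show. They also leave open whether hydrogen in place of chloro would give a similar step in a compound with a methyl-branched amide chain and an aryl group like that of compound 1, since this one pair speaks only for its own trifluoromethyl-bearing setting.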